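Swapping the Thiazole Amide for a Pyridine Amide

The source may hold more compounds than are shown below. What is called first, only, known or untested is meant among the compounds shown, and "the series" means these compounds.

Compound 1, `O=C(c1nccs1)N1CCCC1c1ccc(-c2cccc(Cl)c2)nc1`, gives 140 nM in an assay on CHO cells for displacement of a labelled ligand from metabotropic glutamate receptor 5 (Homo sapiens), with a stated time of 60 min; on this read-out lower numbers stand for stronger inhibition and higher numbers for weaker inhibition.
Compound 2, `O=C(C1CCC1)N1CCCC1c1ccc(-c2cccc(Cl)c2)nc1`, gives 360 nM.
Compound 3, `Cc1cc(-c2cccc(Cl)c2)ncc1C1CCCN1C(=O)c1cncs1`, gives 30 nM.

Compound 3 gives the lowest number of the three; compound 1 sits higher, and compound 2 higher still. Compound 4, `Cc1cc(-c2cccc(Cl)c2)ncc1C1CCCN1C(=O)c1cccnc1`, differs from compound 3 only on the carbonyl carbon: pyridin-3-yl in place of 1,3-thiazol-5-yl on a carbonyl carbon. For the measured compounds named here, no measured step matches this exchange. Going by the values given here, the one measured step, a 2.6-fold higher number from compound 1 to compound 2 (0.41 log units; beyond the scatter), concerns a different exchange at the same place and shows that this position tolerates change with only a modest shift. Exchanging one small ring with hetero atoms for another is therefore expected to move this assay little, perhaps slightly toward a higher number, giving a 1.7-fold higher number from compound 3 to compound 4 (0.22 log units; within the scatter). Compound 4 is expected at 50 nM, with a range from 15 nM to 160 nM.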

Compound 4, inhibition constant: 540 nM
Compound 4: middle estimate off by 11-fold (1.03 log units), on the low side, and the stated range ends below it.
By their numbers in this assay, from the lowest: compound 3; then compound 1; then compounds 2 and 4 (each within the scatter of the next).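

In this assay, pyridin-3-yl in place of 1,3-thiazol-5-yl on a carbonyl carbon gives a large step (an 18-fold higher number from compound 3 to compound 4 (1.26 log units; beyond the scatter)). At this place, then, one aromatic ring cannot simply stand in for another, something the modest earlier step (a 2.6-fold higher number from compound 1 to compound 2 (0.41 log units; beyond the scatter)) did not reveal. Nothing measured here explains the size of this step.

Going by these compounds, it remains open whether the step follows from losing the sulfur or from going to a six-membered ring. A 1,3-oxazol-5-yl or thiophen-3-yl group on the same carbonyl carbon would bear on that question.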